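The source may hold more compounds than are shown below. What is called first, only, known or untested is meant among the compounds shown, and "the series" means these compounds.

Compound 1, `COC(=O)[C@@]1(C)CCC=C2[C@@H]1CC[C@@H](C)[C@]2(C)Cc1c[nH]c2ccc(Cl)cc12`, and compound 3, `COC(=O)[C@@]1(C)CCC=C2[C@@H]1CC[C@@H](C)[C@]2(C)Cc1c(C)[nH]c2ccc(Cl)cc12`, share a core; compound 3 differs from compound 1 by methyl in place of hydrogen on an aromatic carbon. In a functional assay on HBL-100 cells (Homo sapiens) for inhibition, read by sulforhodamine B assay, with a stated time of 48 h (on this read-out lower numbers stand for stronger inhibition of growth and higher numbers for weaker inhibition of growth), compound 1 gives 17000 nM, and in this assay compound 3 gives 15000 nM, so the step of a 1.1-fold lower number from compound 1 to compound 3 (0.05 log units; within the scatter) amounts to nothing that can be told apart from repeat measurement. Compound 2, `COC(=O)[C@@]1(C)CCC=C2[C@@H]1CC[C@@H](C)[C@]2(C)Cc1c[nH]c2ccc(F)cc12`, is made from compound 1 by fluoro in place of chloro on an aromatic carbon; in this assay compound 2 gives 4800 nM, and the step of a 3.5-fold lower number from compound 1 to compound 2 (0.55 log units; beyond the scatter) is the one clear movement among the three measured compounds. Compound 4, `COC(=O)[C@@]1(C)CCC=C2[C@@H]1CC[C@@H](C)[C@]2(C)Cc1c(C)[nH]c2ccc(F)cc12`, is made from compound 3 by fluoro in place of chloro on an aromatic carbon, the same change that separates compound 1 from compound 2, at the same place on the same ring. The expectation for compound 4 therefore rests on compound 1 and compound 2: the change from compound 1 to compound 3 left the number nearly unaltered, as a 1.1-fold lower number from compound 1 to compound 3 (0.05 log units; within the scatter) shows, and the fluoro-for-chloro change measured so far is a 3.5-fold lower number from compound 1 to compound 2 (0.55 log units; beyond the scatter). A step of about that size is expected for compound 4, and the estimated step is a 3.3-fold lower number from compound 3 to compound 4 (0.52 log units; beyond the scatter). On that basis compound 4 is expected to give in this assay about 4500 nM, with a likely span from 2000 nM to 10000 nM. Within the data shown here, with only one measured example of this change, the estimate carries the width of that single comparison.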

Compound 4, concentration for 50% growth inhibition: 14000 nM
Compound 4: the middle estimate sits 3.1-fold (0.49 log units) below what was measured, and the stated range ends below it.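

Fluoro in place of chloro does not carry over from one core to the other in this assay. On the core that bears the added methyl, it gives a 1.1-fold lower number from compound 3 to compound 4 (0.03 log units; within the scatter), so the clear movement seen without the methyl does not recur: the same change on two cores in this assay, a 3.5-fold lower number (0.55 log units; beyond the scatter) from compound 1 to compound 2 and a 1.1-fold lower number (0.03 log units; within the scatter) from compound 3 to compound 4, 3.3-fold (0.52 log units) apart, beyond the scatter of two such steps. Read the other way, methyl in place of hydrogen gives a 2.9-fold higher number from compound 2 to compound 4 (0.46 log units; beyond the scatter), although the same change made no distinguishable difference on the chloro core: the same change on two cores in this assay, a 1.1-fold lower number (0.05 log units; within the scatter) from compound 1 to compound 3 and a 2.9-fold higher number (0.46 log units; beyond the scatter) from compound 2 to compound 4, 3.3-fold (0.52 log units) apart, beyond the scatter of two such steps. The two changes therefore do not add up across these four compounds, with the lower number confined to compound 2, but this square of four compounds does not show why that is so or whether the same dependence would appear on any other core.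

The compounds shown leave open how other groups on the same aromatic carbon, such as bromo, methoxy or nitrile, would behave with and without the methyl, and whether a longer chain such as ethyl would act as the methyl does. They also leave open whether a carboxylic acid or an amide in place of the methyl ester would alter these steps.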